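Aryl sulfonate ureas: iodo for isopropyl on the chloropropyl core

The source may report more compounds than this note shows. Statements on the series, on what has been measured and on what is new or still open speak of the compounds shown alone.

Measured compounds:
- compound 1, `CCCNC(=O)Nc1ccc(S(=O)(=O)Oc2ccccc2C(C)C)cc1`: 680 nM
- compound 2, `CCCNC(=O)Nc1ccc(S(=O)(=O)Oc2ccccc2I)cc1`: 700 nM
- compound 3, `CC(C)c1ccccc1OS(=O)(=O)c1ccc(NC(=O)NCCCCl)cc1`: 2700 nM

All three were read in a functional assay on HT-1080 cells (Homo sapiens) for antiproliferative activity, read by sulforhodamine B assay, with a stated time of 48 h; a higher number here means a weaker inhibitor, a lower number a stronger inhibitor. Compound 1 and compound 2 are separated by iodo in place of isopropyl on an aromatic carbon, and the step of a 1.0-fold higher number from compound 1 to compound 2 (0.01 log units; within the scatter). Compound 3 carries a different core: against compound 1 it shows (chloro in place of hydrogen on a saturated chain carbon, three bonds along the chain from an amide-type nitrogen), and the step of a 4.0-fold higher number from compound 1 to compound 3 (0.60 log units; beyond the scatter). Compound 3 thus stands apart from compound 1 and compound 2 in this assay.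

Compound 4, `O=C(NCCCCl)Nc1ccc(S(=O)(=O)Oc2ccccc2I)cc1`, has not been measured. It differs from compound 3 by iodo in place of isopropyl on an aromatic carbon, the same change as that from compound 1 to compound 2, since the place is described in the same words in both cases. On the core of compound 1 that change left the number essentially unmoved, as seen in a 1.0-fold higher number from compound 1 to compound 2 (0.01 log units; within the scatter). The expectation is that the step of no change at the digits printed from compound 3 to compound 4 (within the scatter) will likewise stay within the scatter, resting only on that single precedent. Compound 4 is therefore estimated at 2700 nM, with a likely range from 1300 nM to 5600 nM in this assay.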

Compound 4, half-maximal inhibitory concentration: 2800 nM
Compound 4: the middle estimate sits 1.0-fold (0.02 log units) below what was measured, and the stated range covers the measured number.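

In this assay, iodo in place of isopropyl again leaves the number level on the core carrying the chloro group, with a 1.0-fold higher number from compound 3 to compound 4 (0.02 log units; within the scatter), and this step agrees with the one on the core of compound 1: the same change on two cores in this assay, a 1.0-fold higher number (0.01 log units; within the scatter) from compound 1 to compound 2 and a 1.0-fold higher number (0.02 log units; within the scatter) from compound 3 to compound 4, 1.0-fold (0.00 log units) apart, within the scatter of two such steps. Read along the other edge of the set, chloro in place of hydrogen on the chain gives a 4.0-fold higher number from compound 2 to compound 4 (0.60 log units; beyond the scatter) with iodo on the aromatic ring, and this agrees with the step seen with isopropyl: the same change on two cores in this assay, a 4.0-fold higher number (0.60 log units; beyond the scatter) from compound 1 to compound 3 and a 4.0-fold higher number (0.60 log units; beyond the scatter) from compound 2 to compound 4, 1.0-fold (0.00 log units) apart, within the scatter of two such steps. The two changes therefore combine without interference across these four compounds, but that rests on two cores in a single assay and does not show why the steps agree or that they would hold on any other core.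

The compounds shown leave open whether bromo, methoxy or plain hydrogen in place of iodo would also leave the number level. They also leave open whether an amine, a hydroxyl or a longer chain at the chain end would shift the number as chloro does.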